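Adding a further fluoro to the shared core

The source may hold more compounds than are shown below. What is called first, only, known or untested is meant among the compounds shown, and "the series" means these compounds.

Within the data shown here, compound 2 `O=c1cc(-c2ccccc2)oc2cc(OCCCCNc3nc4ccc(F)cc4s3)cc(O)c12` gives 14.7 ug/mL in a physicochemical assay, read by spectrophotometry, with a stated time of 25 min (on this read-out higher numbers stand for weaker inhibition and lower numbers for stronger inhibition), the lowest of the two numbers so far. Among the measured compounds shown here, its only neighbour, compound 1 `O=c1cc(-c2ccccc2)oc2cc(OCCCCNc3nc4ccc([N+](=O)[O-])cc4s3)cc(O)c12`, gives 30.3 ug/mL in this assay, and the step of a 2.1-fold lower number from compound 1 to compound 2 (0.31 log units; beyond the scatter) corresponds to fluoro in place of nitro on an aromatic carbon. Compound 3 `O=c1cc(-c2ccccc2)oc2cc(OCCCCNc3nc4c(F)cc(F)cc4s3)cc(O)c12` differs from compound 2 by fluoro in place of hydrogen on an aromatic carbon, which read one bond further out is 6-fluoro-1,3-benzothiazol-2-yl to 4,6-difluoro-1,3-benzothiazol-2-yl. For the measured compounds named here, only the step from compound 1 to compound 2 bears on this, and loosely: it exchanged one group for fluoro rather than adding fluoro for hydrogen, and it was modest. Going by the values given here, no measured pair adds a fluoro in this way, so a small step is expected, if any, with a slight lean toward a lower number. Compound 3 is therefore expected to give 12 ug/mL (range 6 ug/mL to 25 ug/mL), an expected step of a 1.2-fold lower number from compound 2 to compound 3 (0.09 log units; within the scatter) that may well fall within the scatter.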

Compound 3, half-maximal inhibitory concentration: 15.1 ug/mL
The estimate for compound 3 lay 1.3-fold (0.10 log units) below the measured number; the measured number falls inside the stated range.
By their numbers in this assay, from the lowest: compounds 2, 3 and 1 (each within the scatter of the next, the first and the last beyond it).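

In this assay, fluoro in place of hydrogen on the aromatic carbon ortho to a fused ring and meta to the fluoro group gives a 1.0-fold higher number from compound 2 to compound 3 (0.01 log units; within the scatter), so this position shows no readable response to this small change with a fluoro group already on the ring. The exchange of 6-nitro-1,3-benzothiazol-2-yl for 4,6-difluoro-1,3-benzothiazol-2-yl gives a 2.0-fold lower number from compound 1 to compound 3 (0.30 log units; within the scatter), so the second fluoro adds nothing that can be read beyond the scatter. No measurement available here accounts for this flat result.

Going by these compounds, whether this position stays equally flat with a larger group, such as chloro, methoxy or a dimethylamino group, remains open. Also open, on these data alone, is whether the same holds with a different substituent in place of the existing fluoro, such as methyl or nitrile.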